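Swapping cyclopropyl for isopropyl on compound 3

The source may hold more compounds than are shown below. What is called first, only, known or untested is meant among the compounds shown, and "the series" means these compounds.

Measured in an in vitro ADME assay on microsomes from liver (Homo sapiens) for metabolic stability; a higher number here means faster removal of the compound, a lower number slower removal:
- compound 1 `CS(=O)(=O)N[C@H]1CC[C@H](c2n[nH]cc2-c2ccnc(NC3CCCC3)n2)CC1`: 0.011 mL/min/kg
- compound 2 `CC(C)Nc1nccc(-c2c[nH]nc2C2CCN(S(C)(=O)=O)CC2)n1`: 0.012 mL/min/kg
- compound 3 `Clc1ccc(-c2n[nH]cc2-c2ccnc(NC3CC3)n2)cc1`: 0.096 mL/min/kg

Compound 3 has the highest number of the three, and its gaps to compound 1 and to compound 2 both lie beyond the usual scatter of repeat measurements. Compound 4 `CC(C)Nc1nccc(-c2c[nH]nc2-c2ccc(Cl)cc2)n1` differs from compound 3 in one place: isopropyl in place of cyclopropyl on a nitrogen on an aromatic ring. In words, this puts isopropyl in place of cyclopropyl on a nitrogen on an aromatic ring. For the measured compounds named here, no two measured compounds differ in just one place, so there is no direct precedent for this swap. Compound 2 also carries isopropylamino and gives 0.012 mL/min/kg, but it differs from compound 3 elsewhere too, so its low number cannot be credited to that group. The expectation in this assay is therefore no step beyond the scatter, with little confidence in its direction. The expected change is a 1.1-fold lower number from compound 3 to compound 4 (0.05 log units; within the scatter). For compound 4 the estimated value is 0.085 mL/min/kg, with a range of 0.03 mL/min/kg to 0.22 mL/min/kg.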

Compound 4, clearance: 0.106 mL/min/kg
Compound 4: the middle estimate sits 1.2-fold (0.10 log units) below what was measured, within the range that was stated.
By their numbers in this assay, from the lowest: compounds 1 and 2 (each within the scatter of the next); then compounds 3 and 4 (each within the scatter of the next).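

In this assay, for the compounds shown here, the change from cyclopropylamino to isopropylamino gives a 1.1-fold higher number from compound 3 to compound 4 (0.04 log units; within the scatter) and so provides the first direct reading of this swap, since compound 3 and compound 4 differ in this one place only. Going by these compounds alone, replacing the three-membered ring with an open group of the same carbon count, on a nitrogen on an aromatic ring, produces no step that can be told apart from repeat-measurement noise. That finding rests on this single pair, and no measurement shown offers an explanation for it.

As far as these compounds go, whether the same swap would also leave the number unchanged on a different core, such as that of compound 2, remains open. Also open, from the compounds shown here alone, is what a longer chain such as n-butyl, or a group carrying an alcohol or an amine, would do on this nitrogen.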